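Thiophene for Phenyl on an Analgesic Amide Core

This account rests on a few compounds, and the source may have more. Where it says the series, first, only, none or still open, it means among the compounds named here.

Compound 1 `O=C(/N=C1\NC2(CCCCO2)CCS1)c1ccccc1` carries a plain phenyl on its carbonyl carbon. In a functional assay on the whole organism (strain CF-1) with Mus musculus as the target, in the writhing test, with a stated time of 15 min (a lower number here means that less compound is needed, a higher number that more compound is needed for the effect), compound 1 gives 5 mg/kg, the lowest of the three numbers recorded so far. Compound 2 `O=C(/N=C1\NC2(CCCCO2)CCS1)c1ccc([N+](=O)[O-])cc1`, which bears a nitro group on the ring, gives 28 mg/kg in this assay, and compound 3 `N#Cc1ccc(C(=O)/N=C2\NC3(CCCCO3)CCS2)cc1`, with a cyano group there, gives 60 mg/kg. Both steps away from compound 1 go upward: a 5.6-fold higher number from compound 1 to compound 2 (0.75 log units; beyond the scatter) and a 12-fold higher number from compound 1 to compound 3 (1.08 log units; beyond the scatter), while between the two substituted analogues a 2.1-fold higher number from compound 2 to compound 3 (0.33 log units; beyond the scatter).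

Compound 4 `O=C(/N=C1\NC2(CCCCO2)CCS1)c1cccs1` differs from compound 1 in another way: thiophen-2-yl in place of phenyl on a carbonyl carbon. Going by the values given here, none of the measured steps touches this change; all three keep the phenyl and alter only a substituent on it, so they show only that adding a nitro or cyano group raised the number in this assay. Among the compounds with values here, no measured step bears on exchanging the ring itself. A swap of one aromatic ring for a smaller one of similar shape is therefore expected to move the number in this assay only modestly, if at all, and without a clear direction. The expected step is a 1.6-fold higher number from compound 1 to compound 4 (0.20 log units; within the scatter). Compound 4 is estimated to give about 8 mg/kg in this assay, with a range from 3 mg/kg to 25 mg/kg.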

Compound 4, dose for half-maximal effect: 48 mg/kg
Beside the measured number, compound 4's estimate is 6.0-fold (0.78 log units) below it; the measured number lies above the stated range.
By their numbers in this assay, from the lowest: compound 1; then compounds 2, 4 and 3 (each within the scatter of the next, the first and the last beyond it).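

The thiophen-2-yl exchange shows that this position responds to the identity of the ring itself, not only to substituents placed on the phenyl. In this assay the change on the carbonyl carbon gives a 9.6-fold higher number from compound 1 to compound 4 (0.98 log units; beyond the scatter) and so lies beyond the scatter, although the entering ring differs from phenyl only by being five-membered, having one heavy atom fewer, and carrying a sulfur that counts as a hydrogen-bond acceptor. Phenyl therefore remains the group with the lowest number in every measured step from compound 1, now including one that leaves the substituent-free state intact and replaces the ring, and nothing at hand says what lies behind this rise.

The compounds shown leave open whether the rise belongs to thiophen-2-yl alone or to leaving phenyl in general, a question that furan-2-yl, thiophen-3-yl or pyridin-3-yl on the same carbonyl carbon would address. They also leave open whether any substituent on the phenyl can keep the number near that of compound 1, since a methoxy group, a fluorine or a methyl group on the ring would extend the comparison beyond nitro and cyano.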